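Second chloro on the shared core: expectation before measurement

This account rests on a few compounds, and the source may have more. Where it says the series, first, only, none or still open, it means among the compounds named here.

compound 1, `O=C(NCCCCc1ccccc1)n1c(=O)oc2ccc(Cl)cc21`: in an assay on HEK293 cells for inhibition of acid ceramidase (Homo sapiens), with a stated time of 10 min (on this read-out lower numbers stand for stronger inhibition and higher numbers for weaker inhibition), compound 1 gives 15 nM
compound 2, `O=C(NCCCCc1ccccc1)n1c(=O)oc2cc(Cl)ccc21`: in this assay compound 2 gives 33 nM

Compound 2 holds the higher of the two numbers; compound 1 lies lower by a margin beyond the scatter. Compound 3, `O=C(NCCCCc1ccccc1)n1c(=O)oc2cc(Cl)c(Cl)cc21`, differs from compound 2 by chloro in place of hydrogen on an aromatic carbon. For the measured compounds named here, no pair of measured compounds isolates this change. The expected step from compound 2 to compound 3 in this assay, a 1.7-fold lower number from compound 2 to compound 3 (0.22 log units; within the scatter), is a small move toward a lower number, near the edge of the scatter, because compound 1 gives 15 nM with its own chloro pattern. Compound 3 is estimated at 20 nM, ranging from 7 nM to 60 nM.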

Compound 3, half-maximal inhibitory concentration: 18 nM
Beside the measured number, compound 3's estimate is 1.1-fold (0.05 log units) above it, and the stated range covers the measured number.
By their numbers in this assay, from the lowest: compounds 1, 3 and 2 (each within the scatter of the next, the first and the last beyond it).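

In this assay the second chloro can be read from both compounds carrying a single chloro: the step is a 1.8-fold lower number from compound 2 to compound 3 (0.26 log units; within the scatter), and from the other side a 1.2-fold higher number from compound 1 to compound 3 (0.08 log units; within the scatter). Neither step leaves the scatter, so adding chloro at either aromatic carbon of the shared core makes no change that can be told apart on this read-out. Nothing measured here bears on the reason for this result. On these data alone, whether fluoro, methoxy or an amine on the same aromatic carbon would behave like chloro remains open, as does whether the double chloro pattern holds with a longer chain.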